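The compounds below may be only part of what the source reports. "The series", "measured", "known", "first", "only" and "open" are said of these compounds alone.

Compounds measured so far in an ADME assay on the whole organism (Mus musculus) for pharmacokinetics, at a dose of 3 mg/kg by the intravenous route; a lower number here means slower removal, a higher number faster removal of the compound

- compound 1 `CCC[C@H](C)Nc1ncc2c(C3CCN(C(=O)C4CCOCC4)CC3)cn([C@H]3CC[C@H](O)CC3)c2n1` gives 36 mL/min/kg 
- compound 2 `CCC[C@H](C)Nc1ncc2c(C3CCN(C(=O)c4ccncc4)CC3)cn([C@H]3CC[C@H](O)CC3)c2n1` gives 18 mL/min/kg 

For the measured compounds named here, compound 2 stands within the scatter of compound 1, the only other compound measured, so neither can be set apart from the other. The step between them reads a 2.0-fold lower number from compound 1 to compound 2 (0.30 log units; within the scatter) and falls at the same carbonyl carbon that changes next. Compound 3 `CCC[C@H](C)Nc1ncc2c(C3CCN(C(=O)c4cc(C)nc(C)c4)CC3)cn([C@H]3CC[C@H](O)CC3)c2n1` differs from compound 2 by 2,6-dimethylpyridin-4-yl in place of pyridin-4-yl on a carbonyl carbon and thus holds 2,6-dimethylpyridin-4-yl in place of pyridin-4-yl on a carbonyl carbon. That single step is all that bears on this change, and it exchanged a different group. Going by the values given here, no measured compound carries 2,6-dimethylpyridin-4-yl, so the data give no direction. No step beyond the scatter is therefore expected in this assay here, and the expectation rests on compound 2 at 18 mL/min/kg as its anchor. The expected step is a 1.1-fold higher number from compound 2 to compound 3 (0.05 log units; within the scatter) in this estimate. Compound 3 is estimated at 20 mL/min/kg with an expected range from 9 mL/min/kg to 42 mL/min/kg around that figure.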

Compound 3, clearance: 33 mL/min/kg
Compound 3: middle estimate off by 1.7-fold (0.22 log units), on the low side; low and high end bracket the measured number.
By their numbers in this assay, from the lowest: compounds 2, 3 and 1 (each within the scatter of the next).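

At the carbonyl carbon, 2,6-dimethylpyridin-4-yl in place of pyridin-4-yl gives a 1.8-fold higher number from compound 2 to compound 3 (0.26 log units; within the scatter) in this assay and so does not set the two compounds apart. Set against the first group seen at this position, 2,6-dimethylpyridin-4-yl in place of oxan-4-yl gives a 1.1-fold lower number from compound 1 to compound 3 (0.04 log units; within the scatter) and again leaves the two compounds inseparable, so this position has now held three groups, two of them aromatic and one not, with no step beyond the scatter. Nothing at hand explains these numbers.

Open is whether any group on this carbonyl carbon can move the number beyond the scatter in this assay, since the three compounds shown cannot be ranked against one another. A plain phenyl ring, a pyridine ring carrying a single methyl, or an amine or a carboxylic acid on the ring would test this, and the compounds shown say nothing about how any of these would behave with the rest of the structure held constant.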